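The source may report more compounds than this note shows. Statements on the series, on what has been measured and on what is new or still open speak of the compounds shown alone.

Measured compounds in a functional assay on CCRF-CEM cells (Homo sapiens) for cytotoxicity, with a stated time of 72 h; on this read-out lower numbers stand for stronger inhibition and higher numbers for weaker inhibition:

- compound 1, `C#CCOc1ccc(/C=C/C(=O)c2cccc(OC)c2)cc1OC`, gives 5590 nM
- compound 2, `C#CCOc1ccc(/C=C/C(=O)c2cccn2C)cc1OC`, reaches only the assay limit, > 50000 nM
- compound 3, `C#CCOc1ccc(/C=C/C(=O)c2ccccc2C)cc1OC`, gives 6950 nM

Compound 3 thus shows the highest of the two numbers that were read as numbers; its nearest neighbour is compound 1, and the step of a 1.2-fold higher number from compound 1 to compound 3 (0.09 log units; within the scatter) lies within the scatter, so the two cannot be ordered. Compound 2 stands apart as a limit, and the step of an at least 8.9-fold higher number from compound 1 to compound 2 (0.95 log units; beyond the scatter) is beyond the scatter.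

The unmeasured compound 4, `C#CCOc1ccc(/C=C/C(=O)c2cccc(Br)c2)cc1OC`, differs from compound 3 in one place: 3-bromophenyl in place of 2-methylphenyl on a carbonyl carbon. Among the compounds with values here, two measured steps bear on changes at this carbonyl carbon. The exchange of one six-membered aromatic ring of carbon only for another, a 1.2-fold higher number from compound 1 to compound 3 (0.09 log units; within the scatter), changed little, whereas the exchange for 1-methyl-1H-pyrrol-2-yl, an at least 8.9-fold higher number from compound 1 to compound 2 (0.95 log units; beyond the scatter), raised the number well beyond the scatter. Compound 4 keeps a six-membered aromatic ring of carbon only, so the step of a 1.3-fold lower number from compound 3 to compound 4 (0.10 log units; within the scatter) is expected to stay within the scatter in this assay. Compound 4 is therefore estimated at 5500 nM, with a range from 2000 nM to 15000 nM.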

Compound 4, half-maximal inhibitory concentration: 15200 nM
The estimate for compound 4 lay 2.8-fold (0.44 log units) below the measured number, and the stated range ends below it.
By their numbers in this assay, from the lowest: compounds 1 and 3 (each within the scatter of the next); then compound 4. At a limit, above all of these: compound 2.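

The carbon-only six-membered aromatic ring on the carbonyl carbon turns out not to be interchangeable in this assay: a 2.2-fold higher number from compound 3 to compound 4 (0.34 log units; beyond the scatter), whereas the earlier exchange of one such ring for another had stayed within the scatter. The substituent on that ring also counts, since a 2.7-fold higher number from compound 1 to compound 4 (0.43 log units; beyond the scatter), so replacing methoxy with bromo on an aromatic carbon is enough to move the number, and the ring type alone does not fix the result. Compound 4 still differs from the pyrrole compound, an at least 3.2-fold lower number from compound 2 to compound 4 (0.51 log units; beyond the scatter), a step read against a value that is a limit and not a number: the limit of > 50000 nM in this assay, at which 1 of the 4 values shown sits.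

As far as these compounds go, what 3-chlorophenyl, 3-aminophenyl or 3-methylphenyl would give on this carbonyl carbon remains open, so it cannot be said whether the higher number of compound 4 belongs to bromo in particular. Compound 3 and compound 4 differ in both the group and its place on the ring, which leaves the separate contributions of methyl, bromo and their placement unresolved.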